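Fluoro in place of chloro: one step measured, one expected

The compounds below may be only part of what the source reports. "The series", "measured", "known", "first", "only" and "open" are said of these compounds alone.

Measured compounds:
compound 1, `O=C(N/N=C/c1ccccc1Cl)c1cnccn1`, 66%
compound 2, `O=C(N/N=C/c1cccc(Cl)c1)c1cnccn1`, 100%
compound 3, `O=C(N/N=C/c1ccccc1F)c1cnccn1`, 100%

In an ADME assay on J774 cells (Mus musculus) for cytotoxicity, read by MTT assay, with a stated time of 48 h, tested at 100 ug/mL (on this read-out lower numbers stand for a stronger effect and higher numbers for a weaker effect at the one concentration tested), compound 1 gives 66%. Compound 3 differs from compound 1 by fluoro in place of chloro on an aromatic carbon, and this change gives a number 34 percentage points higher from compound 1 to compound 3 (beyond the scatter). Compound 2 gives 100% in this assay, level with compound 3 at the digits printed, so these two together stand highest of the three, with compound 1 the furthest away. How the core of compound 1 and the core of compound 2 differ is not broken down here.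

Compound 4, `O=C(N/N=C/c1cccc(F)c1)c1cnccn1`, has not yet been measured. It differs from compound 2 by fluoro in place of chloro on an aromatic carbon. This is the same kind of change as that from compound 1 to compound 3, but not the same: there the place was ortho to a large group, here it is meta to a large group. Since compound 2 already gives 100%, there is little room for a rise, so in this assay the step is expected to be small, no change at the digits printed from compound 2 to compound 4 (within the scatter). For compound 4 the estimated value is 100%, expected to fall between 85% and 100%.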

Compound 4, a percentage reported as activity, at one concentration (the size of the read-out at that concentration, not a potency): 46%
Compound 4: the middle estimate sits 54 percentage points above what was measured; the whole stated range lies above it.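

In this assay, fluoro in place of chloro on an aromatic carbon gives a number 54 percentage points lower from compound 2 to compound 4 (beyond the scatter). Set beside the earlier step, this shows that the change does not carry from one core to the other in this series, in either size or direction: the same change on two cores in this assay, a number 34 percentage points higher (beyond the scatter) from compound 1 to compound 3 and a number 54 percentage points lower (beyond the scatter) from compound 2 to compound 4, 88 percentage points apart, beyond the scatter of two such steps What these two steps do not show is why the outcomes part ways, since the place of the halogen on the ring is the one thing that differs between the two pairs, and two steps cannot separate an effect of that place from chance features of these compounds, nor give a rule for any further core.

All four compounds shown bear a single chloro or fluoro on the aromatic ring, so it stays open how a methoxy group, an amine or a carboxylic acid at the same places would read in this assay. From the compounds shown here alone, it also stays open which way the same change would go on a core beyond these.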